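A few compounds are considered here, and "the series" means these few. Any claim that something is new, unique, unknown or untested is made for them only; others in the source may bear on it.

Working notes on the series.

Three compounds have been run in a functional assay on SN12C cells (Homo sapiens) for inhibition, read by sulforhodamine B assay, with a stated time of 48 h; on this read-out higher numbers stand for weaker inhibition of growth and lower numbers for stronger inhibition of growth. Compound 1 `Nc1cc(N)c2nc(-c3ccccc3)c(NCc3ccc(Cl)c(Cl)c3)nc2c1` gives 6030 nM and stands lowest of the three numbers. Its nearest neighbour is compound 3 `CCOC(=O)[C@H](CCC(=O)O)NC(=O)c1ccc(Oc2nc3cc(N)cc(N)c3nc2-c2ccccc2)cc1`, which in this assay gives 8710 nM; the gap between compound 1 and compound 3 lies within the scatter, so the two are not separated. Compound 2 `CCOC(=O)[C@H](CCC(=O)O)NC(=O)c1ccc(Sc2nc3cc(N)cc(N)c3nc2-c2ccccc2)cc1` in this assay gives 50100 nM, a gap to compound 1 that lies beyond the scatter. Among the measured compounds shown here, no step between two measured compounds that differ in a single place is available, so the shared core and its substituents have so far not been probed one change at a time.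

Compound 4 `COc1ccc(CNc2nc3cc(N)cc(N)c3nc2-c2ccccc2)cc1` has not yet been measured in this assay. It differs from compound 1 in one place: 4-methoxyphenyl in place of 3,4-dichlorophenyl on a saturated chain carbon bound to a nitrogen on an aromatic ring; cut one bond further out, 3,4-dichlorobenzyl becomes 4-methoxybenzyl. For the measured compounds named here, nothing among the measured compounds shows what such an exchange does here. The step from compound 1 to compound 4 is expected to be small, most likely toward a higher number and probably not beyond the scatter, a 1.5-fold higher number from compound 1 to compound 4 (0.17 log units; within the scatter). For compound 4 in this assay the estimate is 9000 nM, with a range from 3000 nM to 30000 nM.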

Compound 4, concentration for 50% growth inhibition: 17000 nM
Compound 4: middle estimate off by 1.9-fold (0.28 log units), on the low side, and the stated range covers the measured number.
By their numbers in this assay, from the lowest: compounds 1, 3 and 4 (each within the scatter of the next, the first and the last beyond it); then compound 2.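

In this assay the series now has its first reading of a single change: 4-methoxyphenyl in place of 3,4-dichlorophenyl on a saturated chain carbon bound to a nitrogen on an aromatic ring gives a 2.8-fold higher number from compound 1 to compound 4 (0.45 log units; beyond the scatter), a modest step toward weaker inhibition of growth. The position is therefore not indifferent to the aryl group it carries, even though the two groups match in heavy-atom count and each holds one six-membered aromatic ring of carbon only; they differ in that two chlorines leave, and a methoxy group with its one hydrogen-bond acceptor enters. No measured evidence on hand accounts for this step.

A single exchange removes both chlorines and adds the methoxy group at once, so the compounds shown cannot assign the step to either event, and an unsubstituted phenyl, 4-chlorophenyl or 4-methylphenyl at this place would be needed to separate them. Also open, from the compounds shown here alone, is how the position responds to a longer chain between the nitrogen and the ring, or to a carboxylic acid or an amine on that ring.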